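Threonine amides: chain length and an acyl-to-sulfonyl swap

The source may report more compounds than this note shows. Statements on the series, on what has been measured and on what is new or still open speak of the compounds shown alone.

The series shares a threonine-derived core carrying a long saturated chain on the amide nitrogen and an acyl group on the amine nitrogen. Compound 1 `CCCCCCCCCCCCNC(=O)[C@@H](NC(=O)c1ccco1)[C@@H](C)O` gives 67500 nM in a functional assay on MCF7 cells (Homo sapiens) for cytotoxicity, read by MTT assay, with a stated time of 48 h; on this read-out higher numbers stand for weaker inhibition and lower numbers for stronger inhibition. Compound 2 `CCCCCCCCCCCCCCNC(=O)[C@@H](NC(=O)c1ccco1)[C@@H](C)O` gives 105000 nM; the step of a 1.6-fold higher number from compound 1 to compound 2 (0.19 log units; within the scatter) stays within the scatter. Compound 3 `CCCCCCCCCCCCCCCCCCNC(=O)[C@@H](NC(=O)c1ccco1)[C@@H](C)O` gives 21400 nM, the lowest of the three numbers: a 3.2-fold lower number from compound 1 to compound 3 (0.50 log units; beyond the scatter) and a 4.9-fold lower number from compound 2 to compound 3 (0.69 log units; beyond the scatter) both lie beyond the scatter, so compound 3 is the strongest inhibitor among the measured compounds.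

Compound 4 `CCCCCCCCCCCCCCCCCCNC(=O)[C@@H](NS(=O)(=O)c1ccc(C)cc1)[C@@H](C)O` keeps the chain of compound 3 and changes the group on the amine nitrogen: (4-methylphenyl)sulfonyl in place of (furan-2-yl)carbonyl on an amine nitrogen. Within the data shown here, none of the measured steps touches this position; all three concern only the length of the chain on the amide nitrogen. Among the measured compounds shown here, no measured step therefore bears on the change from compound 3 to compound 4, and the direction of any effect in this assay is open. The working expectation is that the number stays near that of compound 3, with an expected step of a 1.2-fold higher number from compound 3 to compound 4 (0.07 log units; within the scatter) not beyond the scatter. For the measured compounds named here, the range is set wide: no measured step constrains this position. Compound 4 is thus estimated at 25000 nM in this assay, with a range from 5000 nM to 120000 nM.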

Compound 4, half-maximal inhibitory concentration: 60100 nM
Estimate against measurement, compound 4: 2.4-fold (0.38 log units) below; the measured number falls inside the stated range.
By their numbers in this assay, from the lowest: compound 3; then compounds 4, 1 and 2 (each within the scatter of the next).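

With the chain on the amide nitrogen held as in compound 3, (4-methylphenyl)sulfonyl in place of (furan-2-yl)carbonyl on the amine nitrogen gives a 2.8-fold higher number from compound 3 to compound 4 (0.45 log units; beyond the scatter) in this assay and so weakens inhibition. The amine nitrogen is therefore a second place where the number moves beyond the scatter, alongside the chain on the amide nitrogen, and at this chain length (furan-2-yl)carbonyl is the stronger of the two groups, though the step is modest and rests on a single pair. Nothing available accounts for the direction or size of this step.

On these data alone, the swap changes the carbonyl to a sulfonyl and the five-membered aromatic ring to a six-membered one together, so the share of each remains open; a benzoyl group or a (furan-2-yl)sulfonyl group on the same nitrogen would separate the two. As far as these compounds go, it also remains open whether the step carries over to the shorter chains of compound 1 and compound 2, or to a longer chain than that of compound 3.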